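One Hydroxyl Shifted: From Compound 1 to Compound 4

The source may hold more compounds than are shown below. What is called first, only, known or untested is meant among the compounds shown, and "the series" means these compounds.

Of the compounds shown here, three sharing one core have been tested in an ADME assay on HEK293 cells (Homo sapiens) for cytotoxicity, read by CCK-8 assay and cell counting, with a stated time of 2 days; a higher number here means a weaker inhibitor, a lower number a stronger inhibitor. Compound 1 `Oc1ccc(-c2cc(-c3ccsc3)nc(-c3cccc(Cl)c3)c2)cc1` gives 2670 nM. Compound 2 `Oc1ccc(-c2cc(-c3ccccc3)nc(-c3ccccc3Cl)c2)cc1` gives 3930 nM, and compound 3 `Oc1cccc(-c2cc(-c3ccco3)nc(-c3ccccc3Cl)c2)c1` gives 1860 nM. These three numbers lie close together: the gap from compound 1 to compound 3 and the gap from compound 1 to compound 2 both fall inside the usual scatter of this assay, so none of the three can be called weaker or stronger than another on this evidence.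

Compound 4 `Oc1cccc(-c2cc(-c3ccsc3)nc(-c3cccc(Cl)c3)c2)c1` has not yet been measured. It differs from compound 1 in one place: 3-hydroxyphenyl in place of 4-hydroxyphenyl on an aromatic carbon A 4-hydroxyphenyl leaves and a 3-hydroxyphenyl enters on an aromatic carbon opposite the ring nitrogen; the two groups match in every counted respect. Compound 3 also carries a 3-hydroxyphenyl group, but it differs from compound 1 elsewhere too, so its value speaks only for itself. For this exact swap nothing has been measured, so the change is expected to be small, a 1.2-fold lower number from compound 1 to compound 4 (0.06 log units; within the scatter), with no clear direction beyond the scatter. Compound 4 is therefore expected to give about 2300 nM, within a range from 1000 nM to 5000 nM.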

Compound 4, half-maximal inhibitory concentration: 3180 nM
The estimate for compound 4 lay 1.4-fold (0.14 log units) below the measured number, within the range that was stated.
By their numbers in this assay, from the lowest: compounds 3, 1, 4 and 2 (each within the scatter of the next, the first and the last beyond it).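

Shifting the hydroxyl from 4-hydroxyphenyl to 3-hydroxyphenyl, on the aromatic carbon opposite the ring nitrogen, gives the first direct reading of this change in this assay: a 1.2-fold higher number from compound 1 to compound 4 (0.08 log units; within the scatter). With the thiophen-3-yl and 3-chlorophenyl groups held fixed, the two hydroxyl placements cannot be told apart in this test, something compounds 1, 2 and 3 could not show, as no two of them differ in only one place. No measurement at hand offers an explanation for this result.

From the compounds shown here alone, it remains open whether the hydroxyl matters at this position at all: a 2-hydroxyphenyl group, a plain phenyl, or a phenyl carrying an amine or a carboxylic acid in its place would test that. Also open, going by these compounds, is whether the same shift reads alike when other groups sit elsewhere on the shared core.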